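Methoxyphenyl position shift on the phenylpiperazine series

The source may hold more compounds than are shown below. What is called first, only, known or untested is meant among the compounds shown, and "the series" means these compounds.

In a functional assay on HEK293 cells with D(4) dopamine receptor (Homo sapiens) as the target, read by FLIPR (a higher number here means that more compound is needed for the effect, a lower number that less compound is needed), compound 3 `CCO/N=C(\CCN1CCN(c2cccc(OC)c2)CC1)c1ccccc1` gives the highest number of the three measured, at 2680 nM; compound 1 `CCO/N=C(\CCN1CCN(c2ccccc2)CC1)c1ccccc1` gives 109 nM and compound 2 `CCO/N=C(\CCN1CCN(c2ccccc2C#N)CC1)c1ccccc1` gives 48.7 nM. For the measured compounds named here, the only measured steps are a 25-fold higher number from compound 1 to compound 3 (1.39 log units; beyond the scatter) and a 2.2-fold lower number from compound 1 to compound 2 (0.35 log units; beyond the scatter). Compound 4 `CCO/N=C(\CCN1CCN(c2ccc(OC)cc2)CC1)c1ccccc1` differs from compound 3 only in 4-methoxyphenyl in place of 3-methoxyphenyl on an amine nitrogen in a ring. Going by the values given here, no measured step moves the methoxy group from one position on the ring to another, and the large rise seen in a 25-fold higher number from compound 1 to compound 3 (1.39 log units; beyond the scatter) says only that introducing methoxy raised the number. The change is therefore expected to give a step of a 2.2-fold lower number from compound 3 to compound 4 (0.35 log units; beyond the scatter) in this assay, with the direction uncertain. Compound 4 is expected to give 1200 nM in this assay, within 250 nM to 6000 nM.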

Compound 4, half-maximal effective concentration: > 10000 nM
Compound 4: no number, only a limit; the forecaster's own chance of this, stated with the estimate: 5%; at least 8.3-fold (0.92 log units) between middle value and limit.
By their numbers in this assay, from the lowest: compound 2; then compound 1; then compound 3. At a limit, above all of these: compound 4.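

Compound 4 gives > 10000 nM in this assay, which is a limit of the assay and not a number. The place of the methoxy group on the ring now has a measured step of its own, an at least 3.7-fold higher number from compound 3 to compound 4 (0.57 log units; beyond the scatter), so its position counts here and not only its presence. As 4-methoxyphenyl, the change is wider still, with an at least 91-fold higher number from compound 1 to compound 4 (1.96 log units; beyond the scatter) and an at least 200-fold higher number from compound 2 to compound 4 (2.31 log units; beyond the scatter).

On these data alone, how far compound 4 lies past its limit stays open, and so does the full size of these steps. As far as these compounds go, whether a hydroxyl or an ethoxy group in place of the methoxy of 4-methoxyphenyl would give the same result also stays open.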